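This account rests on a few compounds, and the source may have more. Where it says the series, first, only, none or still open, it means among the compounds named here.

Of the compounds shown here, two sharing one core have been tested in an ADME assay on HepG2 cells (Homo sapiens) for cytotoxicity, read by MTT assay; a lower number here means a stronger inhibitor, a higher number a weaker inhibitor: compound 1 `O=C(Nc1ccccc1)Oc1ccc(Cl)cc1C(=O)Nc1ccc(F)cc1` and compound 2 `O=C(NC1CCCCC1)Oc1ccc(Cl)cc1C(=O)Nc1ccc(F)cc1`. Compound 1 gives > 20000 nM, which is a limit of the assay and not a number. Going by the values given here, compound 2 gives 21200 nM, the only true number so far in this assay, and it therefore stands alone, with the limit of > 20000 nM in this assay, at which 1 of the 2 values shown sits, as the sole other reference. Among the compounds with values here, the one measured step is a step that the limit leaves unreadable from compound 1 to compound 2, with cyclohexyl in place of phenyl on an amide-type nitrogen, and no size can be taken from it.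

Compound 3 `O=C(NC1CCCCC1)Oc1ccc(Cl)cc1C(=O)Nc1ccc(Br)cc1` has not yet been measured. It differs from compound 2 by bromo in place of fluoro on an aromatic carbon, para to a large group. Within the data shown here, no measured step touches this place, so the data give neither a size nor a direction for the change. The expectation in this assay therefore rests on compound 2 at 21200 nM, with no step beyond the scatter foreseen. The expected result is a 1.2-fold lower number from compound 2 to compound 3 (0.07 log units; within the scatter). For compound 3 the estimated value is 18000 nM, with an expected range of 8000 nM to 40000 nM.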

Compound 3, half-maximal inhibitory concentration: > 50000 nM
Compound 3 ended at the assay's limit; the forecaster's own chance of this, stated with the estimate: 30%; at least 2.7-fold (0.44 log units) between middle value and limit.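

Going by these compounds alone, the 4-fluorophenyl to 4-bromophenyl change gives the first readable step in this assay, an at least 2.3-fold higher number from compound 2 to compound 3 (0.37 log units; beyond the scatter), so at this aromatic carbon, para to a large group, the exchange of fluoro for bromo moves the read-out towards a weaker inhibitor. Within the data shown here, this place therefore responds to a single-atom change in this assay, whereas the only earlier step, on the amide-type nitrogen, cannot be read. The size of the new step is only a lower bound, and its true extent stays hidden, since compound 3 stands at a limit of the assay and not at a number: the limit of > 50000 nM in this assay, at which 1 of the 3 values shown sits.

The compounds shown leave open whether this shift is particular to bromo or would also appear with a methyl, methoxy or hydroxyl group at the same place, and nothing shown gives its cause. They also leave open whether the same exchange would give a step of this direction with phenyl instead of cyclohexyl on the amide-type nitrogen.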